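Swapping the aryl group on the amine of compound 1

The source may hold more compounds than are shown below. What is called first, only, known or untested is meant among the compounds shown, and "the series" means these compounds.

Compound 1 `CCc1ccc(NC2=CC(=O)c3nc4n(c3C2=O)[C@H]2OC[C@@H](O)[C@H]2OC4)cc1` is tested in a functional assay on ECa-109 cells for inhibition, with ECa-109 cell line (Homo sapiens) as the target, read by sulforhodamine B assay (a lower number here means a stronger inhibitor, a higher number a weaker inhibitor), where compound 1 gives 3080 nM. Of the two plain numbers in this set, that is the lower one, though its closest neighbour sits within the usual scatter: compound 2 `COc1cccc(NC2=CC(=O)c3c(nc4n3[C@H]3OC[C@@H](O)[C@H]3OC4)C2=O)c1` gives 3340 nM, so no order between compound 1 and compound 2 can be claimed. Compound 3 `O=C1C(NCc2ccccc2)=CC(=O)c2c1nc1n2[C@H]2OC[C@@H](O)[C@H]2OC1` is reported only as a limit, > 8000 nM, the assay giving no number. Since (the limit of > 8000 nM in this assay, at which 1 of the 3 values shown sits), the measured step of an at least 2.3-fold higher number from compound 2 to compound 3 (0.37 log units; beyond the scatter) shows that replacing an aryl ring by benzyl on the amine nitrogen weakens inhibition.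

The compound to be measured is compound 4 `COc1cccc(NC2=CC(=O)c3nc4n(c3C2=O)[C@H]2OC[C@@H](O)[C@H]2OC4)c1`. Its change from compound 1 is 3-methoxyphenyl in place of 4-ethylphenyl on an amine nitrogen. Going by the values given here, that measured benzyl step does not bear on this aryl-for-aryl exchange, and no measured pair shows exactly it. What the data do show is that compound 1 and compound 2, which carry 4-ethylphenyl and 3-methoxyphenyl on the amine nitrogen but on differently joined cores, lie within the scatter of each other. The expected step is therefore a 1.1-fold higher number from compound 1 to compound 4 (0.03 log units; within the scatter), no change beyond the scatter. Compound 4 is estimated at 3300 nM, expected between 1700 nM and 6500 nM.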

Compound 4, half-maximal inhibitory concentration: 7620 nM
Beside the measured number, compound 4's estimate is 2.3-fold (0.36 log units) below it, and the stated range ends below it.
By their numbers in this assay, from the lowest: compounds 1 and 2 (each within the scatter of the next); then compound 4. At a limit, above all of these: compound 3.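

The aryl group on this amine nitrogen is not a neutral choice: in this assay the exchange gives a 2.5-fold higher number from compound 1 to compound 4 (0.39 log units; beyond the scatter), so 4-ethylphenyl gives the stronger inhibitor of the pair on this core. The earlier step showed only that benzyl in place of an aryl ring costs inhibition, whereas this one keeps a six-membered aromatic ring of carbon directly on the nitrogen and the same count of heavy atoms, and the number still moves, though only modestly. The groups differ in that an oxygen enters, bringing a hydrogen-bond acceptor, yet nothing measured here gives a reason for the step.

The change from 4-ethylphenyl to 3-methoxyphenyl alters both the group on the ring and its place, as the two names show, so the compounds shown cannot separate these two effects. From the compounds shown here alone, how a plain phenyl ring, or a ring carrying an amine or a longer chain, would read on this nitrogen also stays open.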